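The source may report more compounds than this note shows. Statements on the series, on what has been measured and on what is new or still open speak of the compounds shown alone.

Series notes. Compound 1 `CC(C)n1c(/C=C2/C(=O)Nc3ccc(Br)cc32)nc2ccccc21` in a functional assay on PC-3 cells (Homo sapiens) for cytotoxicity, read by MTT assay, with a stated time of 48 h (a lower number here means a stronger inhibitor, a higher number a weaker inhibitor), gives 10700 nM. Compound 2 `CCn1c(/C=C2/C(=O)Nc3ccccc32)nc2ccccc21` in this assay gives 38000 nM. Compound 3 `Cn1c(/C=C2/C(=O)Nc3ccc([N+](=O)[O-])cc32)nc2ccccc21` in this assay gives only a limit, > 50000 nM, so no number is in hand for it. Compound 3 therefore stands at the limit of > 50000 nM in this assay, at which 1 of the 3 values shown sits, while compound 1 and compound 2 each return a number under that limit.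

Compound 4 `Cn1c(/C=C2/C(=O)Nc3ccc(Cl)cc32)nc2ccccc21` is not yet measured in this assay. It differs from compound 3 by chloro in place of nitro on an aromatic carbon; the nitrogen-bound group on the other ring is kept. No measured step between two compounds covers this change, so its size is not known from the shown data. The expectation is a step toward stronger inhibition of a size beyond the usual scatter, though with a limit as the starting point the size itself cannot be fixed. The expected step of an at least 1.6-fold lower number from compound 3 to compound 4 (0.22 log units; that floor lies within the scatter) is set to carry the value into the region where a number is reported. Compound 4 is estimated at 30000 nM, with a range from 8000 nM to 100000 nM, and a real chance that only a limit is again reported.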

Compound 4, half-maximal inhibitory concentration: > 50000 nM
Compound 4: no number, only a limit; the forecaster's own chance of this, stated with the estimate: 35%; at least 1.6-fold (0.22 log units) between middle value and limit.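

Compound 3 and compound 4 both end at a limit, so no step can be read for chloro in place of nitro: the limit of > 50000 nM in this assay, at which 2 of the 4 values shown sit. The compounds shown leave open whether in this assay these two groups differ at all, and how far past the limit either compound lies.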